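Vinyl Enters a Series Still Sitting at the Limit

The source may hold more compounds than are shown below. What is called first, only, known or untested is meant among the compounds shown, and "the series" means these compounds.

Of the compounds shown here, three sharing one core have been tested in a functional assay on BGC-823 cells (Homo sapiens) for cytotoxicity, read by CCK-8 assay, with a stated time of 24 h; a lower number here means a stronger inhibitor, a higher number a weaker inhibitor. Compound 1 `C/C(=C\c1cc(-c2ccc(F)cc2)co1)C(N)=O` gives in this assay only a limit of the assay, > 50000 nM. Compound 2 `C/C(=C\c1cc(-c2ccccc2)cs1)C(N)=O` gives in this assay likewise only a limit, > 50000 nM. Compound 3 `C/C(=C\c1cc(-c2ccccc2C)cs1)C(N)=O` gives in this assay again only a limit, > 50000 nM.

Compound 2 therefore stands nowhere in particular on a scale: it sits at the limit, as do the two other values shown (the limit of > 50000 nM in this assay, at which 3 of the 3 values shown sit). Within the data shown here, the one single-point step among the measured compounds, a step that the two limits leave unreadable from compound 2 to compound 3, runs between two limits and its size cannot be read.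

Compound 4 `C=Cc1ccc(-c2csc(/C=C(\C)C(N)=O)c2)cc1` differs from compound 2 by a single change, (vinyl in place of hydrogen on an aromatic carbon). Among the measured compounds shown here, no measured step with a readable size bears on this change, so no direction and no size beyond the scatter can be drawn from the data for this assay. With every measured value at the limit, compound 4 is expected to stay there as well, and the step from compound 2 to compound 4 is estimated as a step that the limit leaves unreadable from compound 2 to compound 4. Compound 4 is thus expected at 60000 nM in this assay, within a range from 15000 nM to 250000 nM.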

Compound 4, half-maximal inhibitory concentration: > 50000 nM
Compound 4 was reported as a limit; the forecaster's own chance of this, stated with the estimate: 75%; the middle value is on the limit's open side.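

Among these compounds, compound 4, like compound 2, is reported only as a limit, so the change from hydrogen to vinyl gives no step of readable size between them. All the compounds rest at the same point: the limit of > 50000 nM in this assay, at which 4 of the 4 values shown sit. The compounds shown leave open which change to the shared core, if any, would bring a measurable value in this assay.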